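Swapping a halogenated benzyl group on a shared core

The compounds below may be only part of what the source reports. "The series", "measured", "known", "first", "only" and "open" are said of these compounds alone.

Of the compounds shown here, three with one shared core have been tested in a functional assay on SMMC-7721 cells (Homo sapiens) for inhibition, read by MTT assay, with a stated time of 72 h, tested at 10 uM; a higher number here means a stronger effect of the compound at the concentration tested, a lower number a weaker effect. Compound 1, with the structure `Clc1ccc(COc2ccccc2/C=C/C(/C=C/c2ccccn2)=N/Oc2ncnc3cc(Cl)ccc23)cc1`, gives 94.8%. Compound 2, with the structure `Cc1cccc(COc2ccc(/C=C/C(/C=C/c3ccccn3)=N/Oc3ncnc4cccc(C)c34)cc2)c1`, gives 97%, and compound 3, with the structure `Cc1cccc2ncnc(O/N=C(\C=C\c3ccccn3)/C=C/c3ccccc3OCc3ccccc3Cl)c12`, gives 95.7%. Compound 1 sits at the lower edge of these three numbers, yet the numbers of compound 3 and of compound 2 both lie within the usual scatter of it, so the three cannot be told apart on this evidence.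

The next compound is compound 4, with the structure `Fc1ccccc1COc1ccccc1/C=C/C(/C=C/c1ccccn1)=N/Oc1ncnc2cc(Cl)ccc12`. It differs from compound 1 in a single place: 2-fluorophenyl in place of 4-chlorophenyl on a saturated chain carbon bound to an oxygen on an aromatic ring. Among the compounds with values here, no measured pair among the three compounds differs in just this way, so there is no directly comparable step to lean on. Since every number seen so far lies in a narrow band near full inhibition, the step is expected to be small, in no clear direction and not beyond the scatter. Compound 4 is therefore expected to give about 93% in this assay, with a range from 82% to 98%. That corresponds to an expected step of a number 1.8 percentage points lower from compound 1 to compound 4 (within the scatter).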

Compound 4, a percentage reported as inhibition, at one concentration (the size of the read-out at that concentration, not a potency): 94.8%
Estimate against measurement, compound 4: 1.8 percentage points below; the measured number falls inside the stated range.
By their numbers in this assay, from the lowest: compounds 1, 4, 3 and 2 (each within the scatter of the next).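

In this assay, putting 2-fluorobenzyl in place of 4-chlorobenzyl gives no change at the digits printed from compound 1 to compound 4 (within the scatter). Within the data shown here, this is the first direct reading at this position, as the earlier compounds offered no pair differing in one place. In this one pair, the halogen and its place on the phenyl ring change together without a step beyond the scatter, on the core of compound 1. Nothing measured here offers an explanation for this result.

The pair cannot separate the change of halogen from the change of its place on the ring, and a read-out at a single concentration is not a potency. As far as these compounds go, it also remains open whether a benzyl group carrying an amine or a carboxylic acid, or a longer chain between the oxygen and the phenyl ring, would move the read-out beyond the scatter.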